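The source may report more compounds than this note shows. Statements on the series, on what has been measured and on what is new or still open speak of the compounds shown alone.

Three compounds share one core, a sulfonamide-linked arrangement in which a five-membered triazole ring carries a substituted phenyl group, and all were tested in a functional assay on SGC-7901 cells (Homo sapiens) for antiproliferative activity, read by MTT assay, with a stated time of 24 h; on this read-out lower numbers stand for stronger inhibition and higher numbers for weaker inhibition. Compound 1 `Cc1ccc(-n2cc(-c3ccccc3NS(=O)(=O)c3c[nH]c(=O)[nH]c3=O)nn2)cc1` gives 6390 nM in this assay. Compound 2 `O=c1[nH]cc(S(=O)(=O)Nc2ccccc2-c2cn(-c3ccc(Cl)cc3)nn2)c(=O)[nH]1` gives 2700 nM. Compound 3 `Cc1ccccc1-n1cc(-c2cccc(NS(=O)(=O)c3c[nH]c(=O)[nH]c3=O)c2)nn1` gives 9230 nM, the highest number of the three; its gap to compound 1 lies within the scatter, while its gap to compound 2 lies beyond it.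

Compound 4 `O=c1[nH]cc(S(=O)(=O)Nc2cccc(-c3cn(-c4ccccc4F)nn3)c2)c(=O)[nH]1` is not yet measured. It differs from compound 3 in one place: fluoro in place of methyl on an aromatic carbon.

Among the compounds with values here, only one measured step exchanges a group on that same phenyl ring: a 2.4-fold lower number from compound 1 to compound 2 (0.37 log units; beyond the scatter), a halogen replacing a methyl, though at a different position of the ring than the exchange here. Within the data shown here, that step gives modest encouragement that a halogen in place of methyl can lower the number; fluoro and chloro, however, are different halogens, and no measured pair shows fluoro directly. The expectation for compound 4 is therefore a small step downward, a 1.5-fold lower number from compound 3 to compound 4 (0.19 log units; within the scatter), with wide uncertainty. Compound 4 is estimated at 6000 nM in this assay, with a likely range from 2500 nM to 14000 nM.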

Compound 4, half-maximal inhibitory concentration: 16000 nM
Beside the measured number, compound 4's estimate is 2.7-fold (0.43 log units) below it; measured number above the stated range.
By their numbers in this assay, from the lowest: compound 2; then compounds 1, 3 and 4 (each within the scatter of the next, the first and the last beyond it).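

In this assay, going from 2-methylphenyl to 2-fluorophenyl gives a 1.7-fold higher number from compound 3 to compound 4 (0.24 log units; within the scatter), so this exchange cannot be told apart from the usual variation between repeated measurements. On this evidence, the place ortho to a large group accepts either methyl or fluoro without a readable gain, and the lower number seen with a halogen in a 2.4-fold lower number from compound 1 to compound 2 (0.37 log units; beyond the scatter) does not carry over to this different halogen at this different place on the ring. None of the available data bear on why the two groups give results that cannot be separated.

The compounds shown leave open whether any group at this place would move the number beyond the scatter, for example a methoxy group, an amine or a trifluoromethyl group, or simply a hydrogen in place of the methyl or fluoro. They also leave open whether chloro, which gave the lowest number of the set on the other arrangement, would bring the same step when placed ortho to a large group on the core of compound 3.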